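Chloro in Place of Fluoro: Compound 2 to Compound 3

The source may report more compounds than this note shows. Statements on the series, on what has been measured and on what is new or still open speak of the compounds shown alone.

Compound 1 `CC(=O)OCc1ccc2oc(=O)c(C(=O)Oc3cccc(Cl)c3)cc2c1`: 49.1%
Compound 2 `O=C(Oc1cccc(F)c1)c1cc2cc([N+](=O)[O-])ccc2oc1=O`: 53.6%

In a functional assay on HT-1080 cells (Homo sapiens), read by transwell migration, with a stated time of 24 h, tested at 1 uM (a lower number here means a stronger effect, a higher number a weaker effect of the compound at the concentration tested), compound 2 gives 53.6%, the higher of the two numbers measured. Compound 1 gives 49.1%, and that gap lies within the scatter, so no order between the two is claimed. Compound 3 `O=C(Oc1cccc(Cl)c1)c1cc2cc([N+](=O)[O-])ccc2oc1=O` differs from compound 2 by chloro in place of fluoro on an aromatic carbon. Going by the values given here, no measured pair shows this change, so its effect is unknown from these data. The step from compound 2 to compound 3 is expected to be small, with no direction beyond the scatter, and is estimated as a number 3.6 percentage points lower from compound 2 to compound 3 (within the scatter). Compound 3 is expected to give 50% in this assay, within a range from 35% to 65%.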

Compound 3, a percentage reported as activity, at one concentration (the size of the read-out at that concentration, not a potency): 65.8%
Compound 3: the middle estimate sits 15.8 percentage points below what was measured; the measured number lies above the stated range.
By their numbers in this assay, from the lowest: compounds 1 and 2 (each within the scatter of the next); then compound 3.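

In this assay, chloro in place of fluoro on this aromatic carbon gives a number 12.2 percentage points higher from compound 2 to compound 3 (beyond the scatter) with the nitro group held constant, so at this position the two halogens are not interchangeable. With chloro held constant, nitro in place of acetoxymethyl gives a number 16.7 percentage points higher from compound 1 to compound 3 (beyond the scatter) and shows that the read-out also responds to the group on the core. Nothing available explains either step. The compounds shown leave open whether the chloro-for-fluoro step would recur with acetoxymethyl on the core, and how bromo or methoxy on the same aromatic carbon, or an amine in place of nitro, would read.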